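Cytotoxicity in Liver Cells: From Compound 3 to Compound 4

The source may hold more compounds than are shown below. What is called first, only, known or untested is meant among the compounds shown, and "the series" means these compounds.

Of the compounds shown here, three sharing one core have been tested in an ADME assay on HepG2 cells (Homo sapiens) for cytotoxicity, read by CellTiter-Glo and resazurin assay, with a stated time of 72 h; on this read-out higher numbers stand for an effect only at larger amounts of compound and lower numbers for an effect already at smaller amounts. Compound 1, `CC(C)N(Cc1cccc(OCCCCCC(=O)O)c1)C(=O)c1ccc(-c2ccncc2)cc1`, gives in this assay only a limit of the measurement, > 26000 nM. Compound 2, `CC(C)N(Cc1cccc(OCCCCCC(=O)O)c1)C(=O)c1ccc(-c2cccc(C(F)(F)F)c2)cc1`, likewise gives only a limit, > 26000 nM. The step that the two limits leave unreadable from compound 1 to compound 2, 3-(trifluoromethyl)phenyl in place of pyridin-4-yl on an aromatic carbon, therefore cannot be sized. Compound 3, `CCOC(=O)CCCCCOc1cccc(CN(C(=O)c2ccc(-c3cnc(OC)nc3OC)cc2)C(C)C)c1`, also stands at a limit in this assay, > 26000 nM, so its half-maximal effective concentration is not known as a number.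

Compound 4, `CCOC(=O)CCCCCOc1cccc(CN(C(=O)c2ccc(-c3cccc(OC)c3)cc2)C(C)C)c1`, is the untested neighbour of compound 3. The change is 3-methoxyphenyl in place of 2,4-dimethoxypyrimidin-5-yl on an aromatic carbon. No measured step can be read as a number, because of the limit of > 26000 nM in this assay, at which 3 of the 3 values shown sit. Every value shown sits at that same limit, so the expectation for compound 4 is a further value at the limit, with no step beyond the scatter. The step that the limit leaves unreadable from compound 3 to compound 4 is the estimated result. Compound 4 is thus expected to give about 40000 nM in this assay, within 20000 nM to 100000 nM.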

Compound 4, half-maximal effective concentration: > 21000 nM
Compound 4: no number, only a limit; the forecaster's own chance of this, stated with the estimate: 85%; the middle value lies beyond the limit too.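

Among the compounds shown here, compound 3 and compound 4 both give only limits in this assay, not numbers, so no step between them can be read. The compounds shown leave open at what concentration any of them reaches a half-maximal effect, and whether 3-methoxyphenyl in place of 2,4-dimethoxypyrimidin-5-yl alters it.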